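This account rests on a few compounds, and the source may have more. Where it says the series, first, only, none or still open, it means among the compounds named here.

Compound 1 `Oc1cccc(-c2cc(-c3ccccn3)cc(-c3cccc(O)c3)n2)c1` carries a 3-hydroxyphenyl on its core, and in a functional assay on HCT-15 cells (Homo sapiens) for cytotoxicity, read by CCK-8 assay (on this read-out lower numbers stand for stronger inhibition and higher numbers for weaker inhibition), compound 1 gives 3510 nM. Compound 2 `Oc1ccc(-c2cc(-c3ccccn3)cc(-c3cccc(O)c3)n2)cc1` reaches only a limit of this assay, > 50000 nM. That step, an at least 14-fold higher number from compound 1 to compound 2 (1.15 log units; beyond the scatter), comes with the change (4-hydroxyphenyl in place of 3-hydroxyphenyl on an aromatic carbon). Compound 3 `Oc1cccc(-c2cc(-c3cccnc3)cc(-c3ccccc3O)n2)c1` has a different core; how the two cores differ is not broken down here, and in this assay compound 3 gives 8280 nM. Compound 4 `Oc1ccc(-c2cc(-c3cccnc3)cc(-c3ccccc3O)n2)cc1` has not yet been measured; it differs from compound 3 by 4-hydroxyphenyl in place of 3-hydroxyphenyl on an aromatic carbon, the same kind of change as before, though here the place is meta to a 2-hydroxyphenyl group and a pyridin-3-yl group rather than a 3-hydroxyphenyl group and a pyridin-2-yl group. Starting from compound 3, a step like an at least 14-fold higher number from compound 1 to compound 2 (1.15 log units; beyond the scatter) would again carry the number to the limit (the limit of > 50000 nM in this assay, at which 1 of the 3 values shown sits). Compound 4 is therefore expected to show a 7.2-fold higher number from compound 3 to compound 4 (0.86 log units; beyond the scatter). The estimate for compound 4 is 60000 nM.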

Compound 4, half-maximal inhibitory concentration: > 50000 nM
Compound 4 gave a limit, no number; the forecaster's own chance of this, stated with the estimate: 60%; the middle value does not contradict the limit.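

In this assay compound 4 reaches only a limit, > 50000 nM, and not a number. Putting 4-hydroxyphenyl in place of 3-hydroxyphenyl weakens inhibition on this core too, with an at least 6.0-fold higher number from compound 3 to compound 4 (0.78 log units; beyond the scatter), so in these two pairs the direction of the change carries from one core to the other. It does not show that the size of the step carries over as well: the same change on two cores in this assay, an at least 14-fold higher number (1.15 log units; beyond the scatter) from compound 1 to compound 2 and an at least 6.0-fold higher number (0.78 log units; beyond the scatter) from compound 3 to compound 4; the limit leaves it open whether they differ

The compounds shown leave open what other groups at this place would do, such as an aminophenyl group or a phenyl group bearing a carboxylic acid instead of the hydroxyl. They also leave open whether the same change behaves alike on any further core.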